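A Larger Side Chain in Place of a Hydroxy Group

The compounds below may be only part of what the source reports. "The series", "measured", "known", "first", "only" and "open" are said of these compounds alone.

Three compounds have been measured in a functional assay on the whole organism (Tail, strain ICR) with Mus musculus as the target, in the tail flick test, with a stated time of 30 min, at a dose of 25 umol/kg by the oral route; a higher number here means a stronger effect of the compound at the dose given, a lower number a weaker effect:

Compound 1 `O=C(CN(c1ncnc2c1ncn2C1CCCCO1)C1CC1)N[C@@H](CCC(=O)OCc1ccccc1)C(=O)OCc1ccccc1` gives 32.6%
Compound 2 `CC[C@H](C)[C@H](NC(=O)CN(c1ncnc2c1ncn2C1CCCCO1)C1CC1)C(=O)OCc1ccccc1` gives 25.6%
Compound 3 `O=C(CN(c1ncnc2c1ncn2C1CCCCO1)C1CC1)N[C@@H](CO)C(=O)OCc1ccccc1` gives 27.8%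

Compound 3 stands second highest of these three numbers, but all three lie close together: its step from compound 2 is a number 2.2 percentage points higher from compound 2 to compound 3 (within the scatter), and the step from compound 1 to compound 3 is a number 4.8 percentage points lower from compound 1 to compound 3 (within the scatter). The remaining step, a number 7 percentage points lower from compound 1 to compound 2 (within the scatter), is also within the scatter. In every case the shared core is untouched and only the side chain on the amino-acid portion is varied.

Compound 4 `N=C(N)NCCC[C@H](NC(=O)CN(c1ncnc2c1ncn2C1CCCCO1)C1CC1)C(=O)OCc1ccccc1` continues this pattern. Compared with compound 3 it carries a group of 6 heavy atoms (3 carbon, 3 nitrogen; no ring) in place of one oxygen atom, on a saturated chain carbon, two bonds along the chain from an amide-type nitrogen and a carbonyl carbon.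

The step from compound 1 to compound 3 changed exactly this position, and it stayed within the scatter; the other two steps at the neighbouring chain carbon did the same. The expectation for compound 4 is therefore a step of a number 0.2 percentage points higher from compound 3 to compound 4 (within the scatter), with no change beyond the scatter. The estimated value for compound 4 in this assay is 28%, in the range 17% to 40%.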

Compound 4, a percentage reported as activity, at one dose (the size of the read-out at that dose, not a potency): 34.3%
Compound 4: the middle estimate sits 6.3 percentage points below what was measured; measured number inside the range.
By their numbers in this assay, from the lowest: compounds 2, 3, 1 and 4 (each within the scatter of the next).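

In this assay, this chain position now takes a nitrogen-rich group, a group of 6 heavy atoms (3 carbon, 3 nitrogen; no ring) in place of one oxygen atom, and the step stays within the scatter (a number 6.5 percentage points higher from compound 3 to compound 4 (within the scatter)). The same holds when the group is set against the sec-butyl side chain (a number 8.7 percentage points higher from compound 2 to compound 4 (within the scatter)) and against the larger side chain with its six-membered aromatic ring (a number 1.7 percentage points higher from compound 1 to compound 4 (within the scatter)), so side chains with and without nitrogen, and with and without a ring, give no step beyond the scatter across these four compounds. Nothing measured on these compounds accounts for these numbers.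

On these data alone, whether a simple amine or a carboxylic acid at the end of a longer chain would give a step beyond the scatter stays open. As far as these compounds go, these numbers come from one dose, so how the compounds compare in potency also stays open.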